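Compound 3 to compound 4 in the ester series

This account rests on a few compounds, and the source may have more. Where it says the series, first, only, none or still open, it means among the compounds named here.

Among the measured compounds shown here, compound 3 `CCOC(=O)/C=C(C)/C=C/CC(C)CCCC(C)(C)O` gives 4.65 in a physicochemical assay for lipophilicity (on this read-out lower numbers stand for lower lipophilicity and higher numbers for higher lipophilicity), the lowest of the three numbers so far. Its nearest neighbour is compound 2 `CC#CCOC(=O)/C=C(C)/C=C/CC(C)CCCC(C)C` with 6.4, and the furthest is compound 1 `CCC(C)OC(=O)/C=C(C)/C=C/CC(C)CCCC(C)C` with 7.69. Compound 4 `CCOC(=O)/C=C(C)/C=C/CC(C)CCC(=O)C(C)C` is the next one to be measured.

The change from compound 3 to compound 4 is isopropylcarbonyl in place of 2-hydroxy-2-methylpropyl on a saturated chain carbon, four bonds along the chain from a double-bonded chain carbon.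

For the measured compounds named here, the only measured step, a number 1.29 log units lower from compound 1 to compound 2 (beyond the scatter), concerns a change at a different place in the molecule and does not bear directly on the present change. Going by the values given here, no measured pair shows a hydroxyl group being replaced by a carbonyl on the chain, so nothing sets the size of this step. The exchange keeps the heavy-atom count and acceptor count but removes the one hydrogen-bond donor, and in this assay such a change is expected to give a moderate step upward. For compound 4 the expected step is a number 0.55 log units higher from compound 3 to compound 4 (beyond the scatter). Compound 4 is therefore estimated at 5.2, with a range from 4.6 to 5.8.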

Compound 4, partition coefficient: 4.3
Compound 4: the middle estimate sits 0.90 log units above what was measured; measured number outside the range, below it.
By their numbers in this assay, from the lowest: compound 4; then compound 3; then compound 2; then compound 1.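

In this assay, among the compounds shown here, this is the first change read at this position rather than on the oxygen next to the ester carbonyl: isopropylcarbonyl in place of 2-hydroxy-2-methylpropyl on a saturated chain carbon, four bonds along the chain from a double-bonded chain carbon, gives a number 0.35 log units lower from compound 3 to compound 4 (beyond the scatter). The exchange keeps 5 heavy atoms on each side and goes from 1 hydrogen-bond donor to 0 hydrogen-bond donors, so at this position, in this one pair, losing the donor comes with a modest drop in the number rather than a rise. No available evidence accounts for the direction of this step.

Compound 3 and compound 4 differ in both the hydroxyl group and the carbonyl at once, so the pair cannot separate what each contributes to the step. Going by these compounds, it remains open how an amine or a carboxylic acid on this saturated chain carbon would read, and whether the same exchange gives a step of similar size when the ethyl ester is replaced by the sec-butyl or but-2-yn-1-yl ester.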